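A Longer Nitrooxyalkyl Chain on the Shared Core

The source may hold more compounds than are shown below. What is called first, only, known or untested is meant among the compounds shown, and "the series" means these compounds.

Three compounds share one core and differ only in the group on the oxygen next to a carbonyl group. Compound 1 `COc1cc(/C=C/C(=O)OC/C=C/CO[N+](=O)[O-])ccc1O` carries a chain ending in a nitrooxy group; in a functional assay on Calu-1 cells (Homo sapiens) for cytotoxicity, read by resazurin assay, with a stated time of 72 h (a higher number here means a weaker inhibitor, a lower number a stronger inhibitor), compound 1 gives 2480 nM. Compound 2 `COc1cc(/C=C/C(=O)OCCCO[N+](=O)[O-])ccc1O` has the shorter 3-(nitrooxy)propyl chain. In this assay compound 2 gives > 50000 nM, which is a limit of the assay rather than a measured number. Compound 3 `COc1cc(/C=C/C(=O)OC(C)C)ccc1O` bears isopropyl. In this assay compound 3 gives > 50000 nM, again a limit. Compound 2 therefore stands at the weak end of what is shown, since (the limit of > 50000 nM in this assay, at which 2 of the 3 values shown sit). The step of an at least 20-fold higher number from compound 1 to compound 2 (1.30 log units; beyond the scatter) shows that shortening the chain cost much, while a step that the two limits leave unreadable from compound 2 to compound 3. Compound 4 `COc1cc(/C=C/C(=O)OCCCCCCO[N+](=O)[O-])ccc1O` brings the change (3-(nitrooxy)propyl in place of nitrooxy on a saturated chain carbon, three bonds along the chain from an oxygen next to a carbonyl group). Because an at least 20-fold higher number from compound 1 to compound 2 (1.30 log units; beyond the scatter) ran against shortening, some gain on lengthening is expected, though compound 2 sits at a limit and the true size cannot be read. Compound 4 is estimated at 20000 nM, within 5000 nM to 80000 nM, an expected step of an at least 2.5-fold lower number from compound 2 to compound 4 (0.39 log units; beyond the scatter).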

Compound 4, half-maximal inhibitory concentration: > 50000 nM
Compound 4: no number, only a limit; the forecaster's own chance of this, stated with the estimate: 45%; at least 2.5-fold (0.39 log units) between middle value and limit.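

In this assay compound 4 gives > 50000 nM, a limit of the assay and not a number. Among these compounds, compound 2 sits at the same limit, so no step between compound 2 and compound 4 can be read. The compounds shown leave open whether the longer chain of compound 4 changes the true potency at all.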